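Chloromethylbenzyl purines: amino for hydrogen on the core

This account rests on a few compounds, and the source may have more. Where it says the series, first, only, none or still open, it means among the compounds named here.

Three compounds share a chloromethylbenzyl group on a fused bicyclic core. Compound 1 `ClCc1ccccc1Cn1cnc2c(Cl)nc(Cl)nc21` carries two chloro groups on the core and gives 6020 nM in a functional assay on SF-295 cells (Homo sapiens) for cytotoxicity, read by sulforhodamine B assay, with a stated time of 48 h; on this read-out lower numbers stand for higher toxicity in this test and higher numbers for lower toxicity in this test. Compound 2 `ClCc1ccccc1Cn1cnc2c(Cl)ncnc21` keeps one chloro group; in this assay compound 2 gives 51300 nM, the highest of the three numbers. Compound 3 `ClCc1cccc(Cn2cnc3c(Cl)nc(Cl)nc32)c1` moves the chloromethyl group on the benzyl ring and gives 45700 nM; its number and that of compound 2 lie within the scatter of each other. Within the data shown here, the one step that varies a single place, an 8.5-fold higher number from compound 1 to compound 2 (0.93 log units; beyond the scatter), is modest and beyond the scatter.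

Compound 4 `Nc1nc(Cl)c2ncn(Cc3ccccc3CCl)c2n1` differs from compound 2 by amino in place of hydrogen on an aromatic carbon. Among the measured compounds shown here, no measured pair shows an amino group entering anywhere, so the only step of any bearing is the chloro-to-hydrogen step above, which concerns the same aromatic carbon but a different group; it sets the scale of what one change at this position has done, not its direction for an amino group. The expected step is therefore small, a 1.7-fold lower number from compound 2 to compound 4 (0.23 log units; within the scatter), with a wide range. Compound 4 is estimated at 30000 nM in this assay, from 8000 nM to 100000 nM.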

Compound 4, concentration lethal to 50% of the cells: 63100 nM
Estimate against measurement, compound 4: 2.1-fold (0.32 log units) below, within the range that was stated.
By their numbers in this assay, from the lowest: compound 1; then compounds 3, 2 and 4 (each within the scatter of the next).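

In this assay, amino on the aromatic carbon between two ring nitrogen atoms cannot be told apart from hydrogen there: a 1.2-fold higher number from compound 2 to compound 4 (0.09 log units; within the scatter). Chloro is the group at this carbon that stands apart, since replacing it with amino gives a 10-fold higher number from compound 1 to compound 4 (1.02 log units; beyond the scatter), a step beyond the scatter, like the step to hydrogen, an 8.5-fold higher number from compound 1 to compound 2 (0.93 log units; beyond the scatter); compound 3 goes against any reading that chloro alone sets the number, as compound 3 keeps that chloro group and gives 45700 nM with the chloromethyl group moved on the benzyl ring. No measured evidence accounts for the difference between chloro and the other two groups, or for the closeness of hydrogen and amino.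

The compounds shown leave open whether a methoxy group, a dimethylamino group or a longer amine chain at this carbon would also stay within the scatter of compound 2, or would shift the number as chloro does. They also leave open whether amino in place of chloro has a comparable effect when the chloromethyl group sits as in compound 3.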